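Swapping cyano for methoxy on compound 3

This account rests on a few compounds, and the source may have more. Where it says the series, first, only, none or still open, it means among the compounds named here.

Of the compounds shown here, three on a shared core have been measured so far in a functional assay on HL-60 cells (Homo sapiens) for antiproliferative activity, read by CCK-8 assay, with a stated time of 72 h (a lower number here means a stronger inhibitor, a higher number a weaker inhibitor), and differ in one group. Compound 1 `Cc1cc(Nc2cc(N3CCN(C)CC3)nc(Nc3ccc(S(N)(=O)=O)cc3)n2)n[nH]1` carries 4-sulfamoylphenyl and gives 213 nM as its value. Compound 2 `Cc1cc(Nc2cc(N3CCN(C)CC3)nc(Nc3cccc(Cl)c3)n2)n[nH]1` carries 3-chlorophenyl and gives 131 nM as its value. That gap (a 1.6-fold lower number from compound 1 to compound 2 (0.21 log units; within the scatter)) is no real separation. Compound 3 `Cc1cc(Nc2cc(N3CCN(C)CC3)nc(Nc3ccc(C#N)cc3)n2)n[nH]1` carries 4-cyanophenyl and gives 21.8 nM as the lowest of the three numbers, which makes it the strongest inhibitor of the set.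

Compound 4 `COc1ccc(Nc2nc(Nc3cc(C)[nH]n3)cc(N3CCN(C)CC3)n2)cc1` has not been measured. It has methoxy in place of cyano on an aromatic carbon, para to a large group (methoxy in place of cyano on an aromatic carbon). Among the compounds with values here, no measured step brings in methoxy, so the evidence is indirect. The two steps that arrive at cyano are a 9.8-fold lower number from compound 1 to compound 3 (0.99 log units; beyond the scatter) and a 6.0-fold lower number from compound 2 to compound 3 (0.78 log units; beyond the scatter) and both are modest but real. Read backwards, they suggest that leaving cyano tends to raise the number, though two examples make a thin pattern. A rise of similar or smaller size is therefore expected, meaning a weaker inhibitor than compound 3. The estimated step is a 2.8-fold higher number from compound 3 to compound 4 (0.44 log units; beyond the scatter) in this assay and it carries wide uncertainty. The expected value for compound 4 is 60 nM (estimated range 20 nM to 180 nM).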

Compound 4, half-maximal inhibitory concentration: 335 nM
Estimate against measurement, compound 4: 5.6-fold (0.75 log units) below; the whole stated range lies below it.
By their numbers in this assay, from the lowest: compound 3; then compounds 2, 1 and 4 (each within the scatter of the next, the first and the last beyond it).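

In this assay, methoxy in place of cyano at this position, para to a large group, gives a 15-fold higher number from compound 3 to compound 4 (1.19 log units; beyond the scatter) and is the largest step in the set, even though the two groups have the same count of heavy atoms and of hydrogen-bond acceptors. The other two steps show that the low number does not extend to the other groups: the change gives a 1.6-fold higher number from compound 1 to compound 4 (0.20 log units; within the scatter) and also a 2.6-fold higher number from compound 2 to compound 4 (0.41 log units; beyond the scatter) so that, of the four groups on this nitrogen, only 4-cyanophenyl stands clear of all the others. No measurement shown here explains why this exchange has so large an effect.

On these data alone, it remains open whether the low number belongs to cyano alone or would also appear with another group at the same carbon, such as trifluoromethyl, acetyl or a carboxylic acid. The position of the group is also untested for cyano and methoxy, so 3-cyanophenyl and 3-methoxyphenyl would show whether the same gap holds when the group sits elsewhere on the ring.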